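Adding a chloro group to a weak growth inhibitor

The source may hold more compounds than are shown below. What is called first, only, known or untested is meant among the compounds shown, and "the series" means these compounds.

In a functional assay on SNB-75 cells (Homo sapiens) for inhibition, read by sulforhodamine B assay, with a stated time of 48 h (a lower number here means a stronger inhibitor of growth, a higher number a weaker inhibitor of growth), compound 3 `COc1cc(-c2nn(-c3cccc(NC(=O)Nc4cccc(C(F)(F)F)c4)c3)cc2-c2ccncc2)ccc1Cl` gives 4500 nM. Compound 2 `COc1cc(-c2nn(-c3cccc(NC(=O)Nc4cc(C(F)(F)F)cc(C(F)(F)F)c4)c3)cc2-c2ccncc2)ccc1Cl` gives 2070 nM, which leaves compound 3 with the higher of these two numbers and so the weaker growth inhibition. Compound 1 `O=C(Nc1cccc(-n2cc(-c3ccncc3)c(-c3ccc(Cl)c(O)c3)n2)c1)Nc1cccc(C(F)(F)F)c1` reads > 32500 nM, and this is a limit of the assay, not a number.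

Compound 4 `COc1cc(-c2nn(-c3cccc(NC(=O)Nc4ccc(Cl)c(C(F)(F)F)c4)c3)cc2-c2ccncc2)ccc1Cl` differs from compound 3 in one place: chloro in place of hydrogen on an aromatic carbon. A chloro group replaces hydrogen, ortho to a trifluoromethyl group, turning 3-(trifluoromethyl)phenyl into 4-chloro-3-(trifluoromethyl)phenyl.

The most relevant measured step is on that same aromatic ring: a 2.2-fold higher number from compound 2 to compound 3 (0.34 log units; beyond the scatter), where hydrogen replaces a trifluoromethyl group. Read in reverse, it shows that an added group on this ring lowered the number modestly. The other step, an at least 7.2-fold lower number from compound 1 to compound 3 (0.85 log units; beyond the scatter), concerns a methyl on an oxygen elsewhere in the molecule and says little about this change. A chloro group is not a trifluoromethyl group, and one step is thin support, so only a modest lowering is expected in this assay. The expected step is a 2.0-fold lower number from compound 3 to compound 4 (0.31 log units; beyond the scatter). For compound 4 the estimated value is 2200 nM, with an expected range from 900 nM to 5000 nM.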

Compound 4, concentration for total growth inhibition: 10300 nM
Compound 4: the middle estimate sits 4.7-fold (0.67 log units) below what was measured; the measured number lies above the stated range.
By their numbers in this assay, from the lowest: compound 2; then compound 3; then compound 4. At a limit, above all of these: compound 1.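

In this assay, a chloro group in place of hydrogen, ortho to the trifluoromethyl group, moves the number the opposite way from the earlier change on this ring: a 2.3-fold higher number from compound 3 to compound 4 (0.36 log units; beyond the scatter), which makes compound 4 the weaker growth inhibitor of that pair, whereas the earlier step was a 2.2-fold higher number from compound 2 to compound 3 (0.34 log units; beyond the scatter). Adding a group to this ring therefore does not lower the number as such, and these two modest steps show that the outcome depends on the change made, whether in the group that enters, the place it takes, or both. Nothing measured for these compounds accounts for the rise in the number on adding chloro.

Going by these compounds, what remains open is whether this rise belongs to chloro itself or would come with any group on this aromatic carbon, a question that a compound carrying an amine or a carboxylic acid there, with the rest of compound 4 unchanged, could help to settle. It is also open how far the effect of chloro depends on the neighbouring trifluoromethyl group, since every compound shown here carries one on this ring.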